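The source may report more compounds than this note shows. Statements on the series, on what has been measured and on what is new or still open speak of the compounds shown alone.

Three compounds share one core and differ only in the group on the amide-type nitrogen: compound 1 `COc1ccc(NC(=O)C2CCN(C/C=C/c3ccccc3)CC2)cc1`, compound 2 `COc1cccc(NC(=O)C2CCN(C/C=C/c3ccccc3)CC2)c1` and compound 3 `O=C(Nc1cccc(F)c1)C1CCN(C/C=C/c2ccccc2)CC1`. In a functional assay on MGC-803 cells (Homo sapiens) for inhibition, read by MTT assay, with a stated time of 72 h (a lower number here means a stronger inhibitor, a higher number a weaker inhibitor), compound 1 gives 58200 nM, compound 2 gives 37200 nM and compound 3 gives 23300 nM. Compound 3 therefore stands apart from one neighbour but not the other: the gap to the first is a 2.5-fold lower number from compound 1 to compound 3 (0.40 log units; beyond the scatter), whereas the gap to the second is a 1.6-fold lower number from compound 2 to compound 3 (0.20 log units; within the scatter). The remaining pair shows a 1.6-fold lower number from compound 1 to compound 2 (0.19 log units; within the scatter).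

Compound 4 `O=C(Nc1nccs1)C1CCN(C/C=C/c2ccccc2)CC1` has 1,3-thiazol-2-yl in place of 3-fluorophenyl on an amide-type nitrogen. The measured steps only exchange one substituted phenyl group for another, and the largest of them, a 2.5-fold lower number from compound 1 to compound 3 (0.40 log units; beyond the scatter), was modest. None of them tests a five-membered ring, so they give no direction, and no shift beyond the scatter is expected, though with wide uncertainty. The expected change is a 1.3-fold higher number from compound 3 to compound 4 (0.11 log units; within the scatter). For compound 4 the estimated value is 30000 nM, with an expected range of 9000 nM to 90000 nM.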

Compound 4, half-maximal inhibitory concentration: 16400 nM
The estimate for compound 4 lay 1.8-fold (0.26 log units) above the measured number; measured number inside the range.
By their numbers in this assay, from the lowest: compounds 4, 3, 2 and 1 (each within the scatter of the next, the first and the last beyond it).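

On the amide-type nitrogen, a five-membered aromatic ring with 2 hetero atoms can stand in for a six-membered ring of carbon only without a clear change in this assay: 1,3-thiazol-2-yl in place of 3-fluorophenyl gives a 1.4-fold lower number from compound 3 to compound 4 (0.15 log units; within the scatter). Set against the two methoxyphenyl compounds, the thiazole gives a 2.3-fold lower number from compound 2 to compound 4 (0.36 log units; beyond the scatter) and a 3.5-fold lower number from compound 1 to compound 4 (0.55 log units; beyond the scatter), both modest steps, so a group with no methoxy and no fluoro can match the best of the earlier numbers. No measurement here explains why these numbers fall as they do.

As far as these compounds go, it remains open how a pyridyl ring, a cyclohexyl group or a carboxylic acid on the phenyl ring would read on this nitrogen. The rest of the shared core stays the same throughout, so the effect of a longer chain there is also unknown.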